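The source may hold more compounds than are shown below. What is called first, only, known or untested is meant among the compounds shown, and "the series" means these compounds.

Among the measured compounds shown here, the three compounds measured so far share a core in which two aromatic rings are joined through a short saturated chain. Compound 1 `COc1cc(CCc2ccccn2)cc(OC)c1O` carries a pyridin-2-yl group at one end of that chain. In a functional assay on HCT-116 cells (Homo sapiens) for antiproliferative activity, read by MTT assay, with a stated time of 72 h (on this read-out lower numbers stand for stronger inhibition and higher numbers for weaker inhibition), compound 1 gives 3060 nM. Among the three numbers this is the second highest. Compound 2 `COc1ccc(CCc2ccc([N+](=O)[O-])cc2)cc1OC` gives 5970 nM, a value that sits within the usual scatter of compound 1. Compound 3 `COc1ccc(CCc2ccccn2)cc1OC` gives 930 nM, which lies beyond the scatter from compound 1 and is the lowest number of the three.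

Compound 4 `COc1cc(CCc2ccccc2)cc(OC)c1O` has not yet been measured. It differs from compound 1 in a single place: phenyl in place of pyridin-2-yl on a saturated chain carbon, two bonds along the chain from an aromatic carbon. For the measured compounds named here, no pair of measured compounds differs in just this way, so there is no measured step to lean on. Because compound 1 gives 3060 nM, and nothing in the measured set shows the ring swap itself, the expected step from compound 1 to compound 4 is a 1.3-fold higher number from compound 1 to compound 4 (0.12 log units; within the scatter), small and likely within the scatter. The estimate for compound 4 in this assay is 4000 nM, with a range from 1500 nM to 12000 nM.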

Compound 4, half-maximal inhibitory concentration: 530 nM
Estimate against measurement, compound 4: 7.5-fold (0.88 log units) above; the measured number lies below the stated range.
By their numbers in this assay, from the lowest: compounds 4 and 3 (each within the scatter of the next); then compounds 1 and 2 (each within the scatter of the next).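

In this assay, among the compounds shown here, the ring swap gives a 5.8-fold lower number from compound 1 to compound 4 (0.76 log units; beyond the scatter) and this is the first measured sign that the ring on the saturated chain carbon is not interchangeable. Both rings are six-membered, aromatic and without net charge, so the edit is small: a ring nitrogen gives way to carbon, and the hydrogen-bond acceptor counted on pyridin-2-yl goes with it. Nothing available here accounts for why the number moves.

Going by these compounds, whether the nitrogen itself matters, or its place in the ring, stays open, and pyridin-3-yl or pyridin-4-yl at this spot would be needed to tell those apart. Also open, on these data alone, are whether the same swap acts alike on the core of compound 3, and how a longer chain or an amine on the phenyl ring would read out.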